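The source may hold more compounds than are shown below. What is called first, only, known or untested is meant among the compounds shown, and "the series" means these compounds.

Of the compounds shown here, three that share one core have so far been tested in a functional assay on SW-620 cells (Homo sapiens) for inhibition, read by sulforhodamine B assay, with a stated time of 48 h; a higher number here means a weaker inhibitor of growth, a lower number a stronger inhibitor of growth. Compound 1 `O=C(Nc1cccc(-n2cc(-c3ccncc3)c(-c3ccc(Cl)c(O)c3)n2)c1)Nc1ccc(Cl)c(Cl)c1` gives 1460 nM in this assay. Compound 3 `O=C(Nc1cccc(-n2cc(-c3ccncc3)c(-c3ccc(Cl)c(O)c3)n2)c1)Nc1cc(C(F)(F)F)cc(C(F)(F)F)c1` gives 1300 nM. Compound 2 `COc1cc(-c2nn(-c3cccc(NC(=O)c4ccc(Cl)c(C(F)(F)F)c4)c3)cc2-c2ccncc2)ccc1Cl` gives 4750 nM, the highest of the three numbers: compound 1 is the nearest to it and compound 3 the furthest, and both gaps lie beyond the usual scatter of repeated measurements.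

Compound 4 `COc1cc(-c2nn(-c3cccc(NC(=O)Nc4ccc(Cl)c(C(F)(F)F)c4)c3)cc2-c2ccncc2)ccc1Cl` has not yet been measured. It is built from compound 2 by a single change, ((4-chloro-3-(trifluoromethyl)phenyl)amino in place of 4-chloro-3-(trifluoromethyl)phenyl on a carbonyl carbon). Among the measured compounds shown here, compounds 1 and 3 also carry a nitrogen on their carbonyl carbon, but each of them differs from compound 2 in a further place as well, so no pair of measured compounds isolates this one change and the comparison stays loose.

The step of a 2.4-fold lower number from compound 2 to compound 4 (0.38 log units; beyond the scatter) is expected to lower the number, probably a little beyond the scatter, because compound 1 at 1460 nM and compound 3 at 1300 nM both stand well under compound 2. Compound 4 is therefore estimated at 2000 nM, with a range from 700 nM to 6000 nM.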

Compound 4, concentration for 50% growth inhibition: 1290 nM
Compound 4: middle estimate off by 1.6-fold (0.19 log units), on the high side; low and high end bracket the measured number.
By their numbers in this assay, from the lowest: compounds 4, 3 and 1 (each within the scatter of the next); then compound 2.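

In this assay, replacing 4-chloro-3-(trifluoromethyl)phenyl on a carbonyl carbon with (4-chloro-3-(trifluoromethyl)phenyl)amino gives a 3.7-fold lower number from compound 2 to compound 4 (0.57 log units; beyond the scatter). Among the compounds shown here, this pair provides the first clean reading of the change, since the earlier compounds with a nitrogen in this place also differed elsewhere: here the entering group adds only one nitrogen and one hydrogen-bond donor, and the step is modest but lies beyond the scatter. Nothing in the available data explains why the number falls.

The pair cannot show whether the added nitrogen itself or its hydrogen matters, or whether the same step would appear with a different aromatic ring on that nitrogen. As far as these compounds go, a carbamate, with an oxygen in place of the added nitrogen, or a methyl group on that nitrogen would each separate these possibilities further, and their effect at this carbonyl carbon remains open.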